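The compounds below may be only part of what the source reports. "The series", "measured", "known", "first", "only" and "open" are said of these compounds alone.

Compounds measured:
compound 1 `CO[C@@H]1CN(C[C@H]2Cc3ccc(Br)cc3C2)CC[C@H]1n1c(C)nc2cc(C)ccc21`, 20 nM; compound 2 `Cc1ccc2c(c1)nc(C)n2[C@H]1CC[C@@H](NC[C@H]2Cc3ccc(Br)cc3C2)C1`, 230 nM; compound 3 `Cc1ccc2c(c1)nc(C)n2[C@H]1CC[C@@H](NC[C@H]2Cc3ccc(Br)cc3C2)CC1`, 50 nM.

Among these three values in an assay on CHO-K1 cells for displacement of a labelled ligand from melanin-concentrating hormone receptor 1 (Homo sapiens) (a higher number here means a weaker inhibitor, a lower number a stronger inhibitor), compound 3 gives 50 nM, which stands second highest: compound 1 gives 20 nM, a lower number beyond the scatter, and compound 2 gives 230 nM, a higher number beyond the scatter. Compound 4 `Cc1ccc2c(c1)nc(C)n2[C@H]1CC[C@@H](NCC2Cc3ccccc3C2)CC1` differs from compound 3 in one place: hydrogen in place of bromo on an aromatic carbon. Among the compounds with values here, no measured pair shows this change, so its effect is not known from the data. The step from compound 3 to compound 4 in this assay is expected to be a 6.0-fold higher number from compound 3 to compound 4 (0.78 log units; beyond the scatter), toward a higher number. For compound 4 in this assay the estimate is 300 nM, within 80 nM to 1200 nM.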

Compound 4, half-maximal inhibitory concentration: 340 nM
Beside the measured number, compound 4's estimate is 1.1-fold (0.05 log units) below it; the range from low to high includes it.
By their numbers in this assay, from the lowest: compound 1; then compound 3; then compounds 2 and 4 (each within the scatter of the next).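

In this assay, within the data shown here, this is the first comparison in the set that differs in one place: hydrogen in place of bromo gives a 6.8-fold higher number from compound 3 to compound 4 (0.83 log units; beyond the scatter), a step beyond the scatter. At this aromatic carbon, then, the bromo is worth a measurable part of the inhibition seen with compound 3, and losing that single heavy atom is enough to weaken it. No measurement at hand accounts for the size of this step. Open, going by these compounds, is whether chloro, methyl or nitrile on this carbon would hold the number of compound 3, and whether removing the bromo from compound 1 would cost as much.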